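Aryl sulfonyl variation in an octadecyl threonine amide series

A few compounds are considered here, and "the series" means these few. Any claim that something is new, unique, unknown or untested is made for them only; others in the source may bear on it.

Measured compounds:
compound 1 `CCCCCCCCCCCCCCCCCCNC(=O)[C@@H](NS(=O)(=O)c1ccc(C)cc1)[C@@H](C)O` — 34000 nM
compound 2 `CCCCCCCCCCCCCCCCCCNC(=O)[C@@H](NS(=O)(=O)c1cccs1)[C@@H](C)O` — only the limit > 200000 nM

In a functional assay on A-431 cells (Homo sapiens) for cytotoxicity, read by MTT assay, with a stated time of 48 h (on this read-out lower numbers stand for stronger inhibition and higher numbers for weaker inhibition), compound 1 gives 34000 nM. Compound 2 reaches only the limit > 200000 nM in this assay, so it stands at a boundary rather than a number (the limit of > 200000 nM in this assay, at which 1 of the 2 values shown sits). Going by the values given here, the one step measured on the sulfonyl substituent, an at least 5.8-fold higher number from compound 1 to compound 2 (0.76 log units; beyond the scatter), is beyond the scatter, with the thiophene member the weaker.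

Compound 3 `CCCCCCCCCCCCCCCCCCNC(=O)[C@@H](NS(=O)(=O)c1ccc2ccccc2c1)[C@@H](C)O` differs from compound 2 by naphthalen-2-yl in place of thiophen-2-yl on a sulfonyl sulfur. Because of an at least 5.8-fold higher number from compound 1 to compound 2 (0.76 log units; beyond the scatter), replacing the thiophenyl with a carbon-only aromatic group is expected to bring the number back down, at least to the region of compound 1. The step from compound 2 to compound 3 is therefore expected to be an at least 10-fold lower number from compound 2 to compound 3 (1.00 log units; beyond the scatter). Compound 3 is estimated at 20000 nM, with a range from 5000 nM to 100000 nM.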

Compound 3, half-maximal inhibitory concentration: 23700 nM
For compound 3 the middle estimate is 1.2-fold (0.07 log units) below the measured one, and the stated range covers the measured number.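

With naphthalen-2-yl on the sulfonyl sulfur, this assay shows an at least 8.4-fold lower number from compound 2 to compound 3 (0.92 log units; beyond the scatter), so the loss seen with thiophen-2-yl does not extend to this two-ring carbon aromatic group. The comparison with the 4-methylphenyl member gives a 1.4-fold lower number from compound 1 to compound 3 (0.16 log units; within the scatter), so compound 1 and compound 3 cannot be told apart here, and the second six-membered aromatic ring brings no measurable gain. The first of these steps is only a bound, as compound 2 stands at a limit of the assay: the limit of > 200000 nM in this assay, at which 1 of the 3 values shown sits.

Open, going by these compounds, is whether a pyridin-3-yl group or a phenyl ring bearing a carboxylic acid on the sulfonyl sulfur would stay in the range of compound 1 and compound 3 or fall away as thiophen-2-yl does. Also open, on these data alone, is whether these sulfonyl comparisons hold with a dodecyl chain in place of the octadecyl chain.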